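Working notes on compounds 1 to 4

The source may hold more compounds than are shown below. What is called first, only, known or untested is meant among the compounds shown, and "the series" means these compounds.

Measured so far:
compound 1 `Nc1ccccc1NC(=O)c1ccc(CSC(=S)N2CCN(Cc3ccccn3)CC2)cc1`: 65.2%
compound 2 `CCN(Cc1ccncc1)C(=S)SCc1ccc(C(=O)Nc2ccccc2N)cc1`: 85.2%
compound 3 `CC1CCN(C(=S)SCc2ccc(C(=O)Nc3ccccc3N)cc2)CC1`: 81.9%

All three were tested in a functional assay on MGC-803 cells (Homo sapiens) for antiproliferative activity, read by CCK-8 assay, with a stated time of 72 h, tested at 8 uM; on this read-out lower numbers stand for a weaker effect and higher numbers for a stronger effect at the one concentration tested. Compound 1 stands lowest of the three numbers; compound 3 lies nearest and compound 2 furthest, both beyond the scatter. For the measured compounds named here, the only measured step, a number 3.3 percentage points lower from compound 2 to compound 3 (within the scatter), exchanges the group on the thiocarbonyl carbon and stays within the scatter. Compound 4 `Nc1ccccc1NC(=O)c1ccc(CSC(=S)N2CCN(c3ncccn3)CC2)cc1` is not yet measured; it differs from compound 1 by pyrimidin-2-yl in place of (pyridin-2-yl)methyl on an amine nitrogen in a ring. Going by the values given here, no measured step touches the group on the amine nitrogen in the ring, so the small step from compound 2 to compound 3 is the only guide. For compound 4 the expected step is a number 2.8 percentage points higher from compound 1 to compound 4 (within the scatter), none beyond the scatter in either direction. Compound 4 is therefore estimated at 68%, between 50% and 86%.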

Compound 4, a percentage reported as inhibition, at one concentration (the size of the read-out at that concentration, not a potency): 64.8%
Compound 4: the middle estimate sits 3.2 percentage points above what was measured; the range from low to high includes it.
By their numbers in this assay, from the lowest: compounds 4 and 1 (each within the scatter of the next); then compounds 3 and 2 (each within the scatter of the next).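

In this assay, pyrimidin-2-yl in place of (pyridin-2-yl)methyl on the amine nitrogen in the ring gives a number 0.4 percentage points lower from compound 1 to compound 4 (within the scatter), the first step read at this position. On this one pair, the read-out at the single concentration tested does not separate the two aromatic groups. No measurement at hand bears on why the two groups read alike.

As far as these compounds go, whether a longer chain or a carboxylic acid on this nitrogen would give a similar reading stays open. A single concentration also leaves any difference in potency between compound 1 and compound 4 open.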